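Swapping a phenyl for a methylpyridinyl on the amine nitrogen

The source may hold more compounds than are shown below. What is called first, only, known or untested is meant among the compounds shown, and "the series" means these compounds.

Measured compounds:
- compound 1, `O=c1cc(CN(c2ccccc2)c2cccc(Cl)c2)c2ccc(F)c(F)c2[nH]1`: 1500 nM
- compound 2, `O=c1cc(CN(Cc2ccccn2)c2cnccn2)c2ccc(F)c(F)c2[nH]1`: 78 nM

Both compounds were tested in an assay on HEK293 cells for inhibition of Nitric oxide synthase, inducible (Homo sapiens), read by fluorescence; a lower number here means a stronger inhibitor, a higher number a weaker inhibitor. Compound 1 gives 1500 nM, the higher of the two numbers and therefore the weaker inhibitor in this pair. Compound 2 gives 78 nM, a much lower number that lies well beyond the scatter of the measurement. Compound 2 differs from compound 1 in more than one place, so the two values show only that a variant carrying nitrogen-containing aromatic rings on the amine nitrogen is the stronger inhibitor; which change is responsible cannot be read from them.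

Within the data shown here, compound 3, `Cc1cccnc1N(Cc1cc(=O)[nH]c2c(F)c(F)ccc12)c1cccc(Cl)c1`, is the first single change made to compound 1: 3-methylpyridin-2-yl in place of phenyl on a nitrogen on an aromatic ring. The chlorophenyl group and the shared core stay as they are. Among the measured compounds shown here, since no step between measured compounds isolates this change, the expectation rests only on the direction suggested by compound 2. A modest gain in potency is expected, so the step of a 2.5-fold lower number from compound 1 to compound 3 (0.40 log units; beyond the scatter) is estimated to be small but likely beyond the scatter. For compound 3 the estimate in this assay is 600 nM, with a range from 200 nM to 2000 nM.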

Compound 3, half-maximal inhibitory concentration: 350 nM
The estimate for compound 3 lay 1.7-fold (0.23 log units) above the measured number; measured number inside the range.
By their numbers in this assay, from the lowest: compound 2; then compound 3; then compound 1.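

In this assay the replacement of phenyl by 3-methylpyridin-2-yl on this nitrogen brings a 4.3-fold lower number from compound 1 to compound 3 (0.63 log units; beyond the scatter) and leaves the chlorophenyl group and the shared core as they were. Among these compounds, this is the first comparison that changes one place only, so it shows what compound 1 and compound 2 could not: a change to this one group is enough on its own to produce a difference beyond the scatter, even with the chlorophenyl group still present. No measurement here explains why the number falls, so the result records the size and direction of this step but not its cause.

The entering group brings a ring nitrogen and a methyl at once, so these compounds cannot tell which of the two accounts for the step, or whether both are needed. A pyridine ring without the methyl and a phenyl ring carrying a methyl, each placed on this same nitrogen with the chlorophenyl group kept, would separate the two contributions, while a morpholine or a longer chain at this place remains an open question.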